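This account rests on a few compounds, and the source may have more. Where it says the series, first, only, none or still open, it means among the compounds named here.

Measured so far:
- compound 1, `C1=C(c2cccnc2)C[C@@H]2CNC[C@H]1C2`: 0.1 nM
- compound 2, `CN1C[C@@H]2C=C(c3cccnc3)C[C@@H](C2)C1`: 9.4 nM

Going by the values given here, in an in vitro assay on SH-EP1 cells for displacement of a labelled ligand from Neuronal acetylcholine receptor; alpha4/beta2 (Homo sapiens) (a higher number here means a weaker inhibitor, a lower number a stronger inhibitor), compound 1 gives 0.1 nM, the lowest of the two numbers measured; the only neighbour is compound 2, which gives 9.4 nM in this assay. Among the compounds with values here, the one measured step, a 94-fold higher number from compound 1 to compound 2 (1.97 log units; beyond the scatter), comes from a methyl replacing a hydrogen on the amine nitrogen in the ring, a change of atoms, not of shape.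

Compound 3, `C1=C(c2cccnc2)CC2CNCC1C2`, differs from compound 1 in a different way: the two compounds have the same atoms and bonds; at least one stereo element is drawn with a configuration in one of them and without one in the other: 2 of 2 stereo elements differ; a stereocentre at a saturated ring carbon is drawn R in compound 1 and without a configuration in compound 3; a stereocentre at a saturated ring carbon is drawn S in compound 1 and without a configuration in compound 3. In words, compound 3 is the same molecule with the handedness of its two ring carbons left unspecified, so it may be the same material as compound 1 or a mixture of both mirror-image forms. Within the data shown here, no measured step here involves such a change; the step from compound 1 to compound 2 concerns a substituent and does not bear on it. If compound 3 is the pure form, no difference beyond the scatter is expected; if it is a mixture in which only one mirror image binds, a small weakening is expected. Compound 3 is therefore estimated at 0.2 nM in this assay, within 0.08 nM to 0.8 nM, a step of a 2.0-fold higher number from compound 1 to compound 3 (0.30 log units; within the scatter).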

Compound 3, inhibition constant: 0.2 nM
The estimate for compound 3 equals the measured number at the digits printed; the measured number falls inside the stated range.
By their numbers in this assay, from the lowest: compounds 1 and 3 (each within the scatter of the next); then compound 2.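

In this assay, the step is a 2.0-fold higher number from compound 1 to compound 3 (0.30 log units; within the scatter), so compounds 1 and 3 cannot be told apart, whereas the methyl on the amine nitrogen in the ring gave a 94-fold higher number from compound 1 to compound 2 (1.97 log units; beyond the scatter). Any reading of this pair concerns stereochemistry alone, because the atoms and bonds are the same and only the drawing of the two ring carbons differs: the fact that one of compounds 1 and 3 is drawn with a defined configuration and the other without, at the place where they differ. The result therefore shows that a compound drawn without these two configurations can still give a number in the same range as compound 1, but the drawing does not reveal whether compound 3 is the same material or a mixture of both mirror images, so it cannot show how much handedness matters at these carbons.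

The compounds shown leave open how the opposite mirror image of compound 1 would behave on its own, which is the direct test of that question. They also leave open whether the large step seen with methyl is specific to that group, or whether an ethyl group or a longer chain on the same nitrogen would give a similar step.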